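The source may hold more compounds than are shown below. What is called first, only, known or untested is meant among the compounds shown, and "the series" means these compounds.

Compounds 1, 2 and 3 share one core, and in a functional assay on K562 cells (Homo sapiens) for cytotoxicity, read by CCK-8 assay, with a stated time of 72 h (on this read-out lower numbers stand for stronger inhibition and higher numbers for weaker inhibition), compound 1 `COc1ccccc1/C=c1/[nH]c(=O)/c(=C\c2ccccc2OC)[nH]c1=O` gives "not active" (no number reported). Compound 3 `C=CCn1c(=O)/c(=C\c2cccc(Br)c2)[nH]c(=O)/c1=C\c1cccc(Br)c1` likewise gives "not active" (no number reported) in this assay. Compound 2 `C=CCn1c(=O)/c(=C\c2cccc(F)c2)[nH]c(=O)/c1=C\c1ccccc1OC` is the only one of the three with a number, giving 4100 nM in this assay. Compound 4 `C=CCn1c(=O)/c(=C\c2ccccc2F)[nH]c(=O)/c1=C\c1ccccc1OC` has not been measured; it differs from compound 2 by 2-fluorophenyl in place of 3-fluorophenyl on a double-bonded chain carbon bound to an aromatic carbon. Among the measured compounds shown here, no measured pair shows this change, so the size of its effect in this assay is open; a small step, within the usual scatter or only a little beyond it, is expected, with no clear direction. Compound 4 is therefore estimated at 5000 nM, between 2000 nM and 15000 nM, an expected step of a 1.2-fold higher number from compound 2 to compound 4 (0.09 log units; within the scatter).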

Compound 4, half-maximal inhibitory concentration: 5600 nM
The estimate for compound 4 lay 1.1-fold (0.05 log units) below the measured number, and the stated range covers the measured number.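

In this assay, among the compounds shown here, 2-fluorophenyl in place of 3-fluorophenyl on a double-bonded chain carbon bound to an aromatic carbon gives a 1.4-fold higher number from compound 2 to compound 4 (0.14 log units; within the scatter), the first comparison in which only this place differs. This read-out therefore does not separate these two fluorophenyl groups at this position. Nothing available gives a reason for this result. From the compounds shown here alone, whether a carboxylic acid or a dimethylamino group in place of the fluorine would give a different number remains open. So does the effect of a 4-fluorophenyl group at this place.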